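The source may hold more compounds than are shown below. What is called first, only, known or untested is meant among the compounds shown, and "the series" means these compounds.

Measured in a functional assay on SMMC-7721 cells (Homo sapiens) for inhibition, read by CCK-8 assay, with a stated time of 72 h; on this read-out higher numbers stand for weaker inhibition and lower numbers for stronger inhibition:
- compound 1 `Nc1ccccc1NC(=O)c1ccc(CNC(=O)c2n[nH]cc2NC(=O)c2ccccc2Cl)cc1`: 12900 nM
- compound 2 `Nc1ccccc1NC(=O)c1ccc(CNC(=O)c2n[nH]cc2NC(=O)c2ccccc2)cc1`: 6620 nM
- compound 3 `Nc1ccccc1NC(=O)c1ccc(CNC(=O)c2n[nH]cc2NC(=O)c2ccccc2F)cc1`: 6850 nM

Compound 3 stands at 6850 nM, within the scatter of both other compounds, so the three cannot be ranked. Compound 4 `COc1ccccc1C(=O)Nc1c[nH]nc1C(=O)NCc1ccc(C(=O)Nc2ccccc2N)cc1` differs from compound 3 in one place: methoxy in place of fluoro on an aromatic carbon. This puts methoxy in place of fluoro on an aromatic carbon, ortho to a large group.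

Among the measured compounds shown here, three measured steps concern this same place: a 1.9-fold lower number from compound 1 to compound 2 (0.29 log units; within the scatter), a 1.9-fold lower number from compound 1 to compound 3 (0.27 log units; within the scatter) and a 1.0-fold higher number from compound 2 to compound 3 (0.01 log units; within the scatter). All three lie within the scatter. None of them involves methoxy, so the evidence is indirect. Since hydrogen, fluoro and chloro at this place gave values that cannot be told apart, no step beyond the scatter is expected in this assay, and no clear direction is expected either.

The expected change is a 1.2-fold higher number from compound 3 to compound 4 (0.07 log units; within the scatter). Compound 4 is estimated at 8000 nM, with an expected range of 3500 nM to 18000 nM.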

Compound 4, half-maximal inhibitory concentration: 8320 nM
Beside the measured number, compound 4's estimate is 1.0-fold (0.02 log units) below it; measured number inside the range.
By their numbers in this assay, from the lowest: compounds 2, 3, 4 and 1 (each within the scatter of the next).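

In this assay the move to methoxy gives a 1.2-fold higher number from compound 3 to compound 4 (0.08 log units; within the scatter) and a 1.3-fold higher number from compound 2 to compound 4 (0.10 log units; within the scatter) and also a 1.6-fold lower number from compound 1 to compound 4 (0.19 log units; within the scatter) so a group of two heavy atoms carrying a hydrogen-bond acceptor behaves here like the smaller groups before it. With methoxy added, hydrogen, fluoro, chloro and methoxy on this aromatic carbon, ortho to a large group, still cannot be told apart, and this position has yet to show any step beyond the scatter in this read-out. No measurement is available that would explain this lack of separation.

Going by these compounds, whether an amine, a carboxylic acid or a longer chain such as butoxy at this place would move the number beyond the scatter stays open. The compounds shown also leave open whether this flat picture holds in any other cell line.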